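The source may report more compounds than this note shows. Statements on the series, on what has been measured and on what is new or still open speak of the compounds shown alone.

In a functional assay on MCF7 cells (Homo sapiens) for cytotoxicity, read by WST assay, with a stated time of 72 h (on this read-out higher numbers stand for weaker inhibition and lower numbers for stronger inhibition), compound 1 `O=C1Nc2c(ccc(F)c2F)C1(c1ccccc1)c1ccc(O)cc1` gives 7.1 nM, the lower of the two actual numbers available. Compound 3 `COc1ccc(C2(c3cccc(O)c3)C(=O)Nc3c2ccc(F)c3F)cc1` gives 196 nM, the other number. Compound 2 `CCCCCOc1ccc(C2(c3ccc(O)cc3)C(=O)Nc3c2ccc(F)c3F)cc1` reads > 1000 nM, which is a limit of the assay and not a number.

Compound 4 `O=C1Nc2c(ccc(F)c2F)C1(c1ccc(O)cc1)c1ccc(F)c(F)c1` keeps the core of compound 1 and makes a single change, 3,4-difluorophenyl in place of phenyl on a saturated ring carbon.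

Within the data shown here, only one measured step bears on this change, since it also adds a group to that phenyl. This step, pentyloxy in place of hydrogen on an aromatic carbon, is large: an at least 140-fold higher number from compound 1 to compound 2 (2.14 log units; beyond the scatter). It brings in a pentyloxy chain rather than fluorine, so it is only a loose guide. In this assay, a modest rise in the number is therefore expected, far smaller than that step. The expected change is a 3.5-fold higher number from compound 1 to compound 4 (0.55 log units; beyond the scatter). For compound 4 the estimated value is 25 nM, with an expected range of 5 nM to 120 nM.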

Compound 4, half-maximal inhibitory concentration: 7.8 nM
Compound 4: the middle estimate sits 3.2-fold (0.51 log units) above what was measured, and the stated range covers the measured number.
By their numbers in this assay, from the lowest: compounds 1 and 4 (each within the scatter of the next); then compound 3. At a limit, above all of these: compound 2.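

In this assay, 3,4-difluorophenyl in place of phenyl on a saturated ring carbon stays within the scatter: a 1.1-fold higher number from compound 1 to compound 4 (0.04 log units; within the scatter). Among these compounds, this shows that the phenyl of compound 1 can carry added atoms without a loss beyond the scatter, which the only earlier step at this phenyl could not show, since that step, an at least 140-fold higher number from compound 1 to compound 2 (2.14 log units; beyond the scatter), ends at a limit for compound 2 and brings in a pentyloxy chain. Nothing measured here explains why 3,4-difluorophenyl and phenyl read alike.

Where between these two outcomes the tolerance of this phenyl gives way remains open, as ethoxy, an amine or a carboxylic acid on it could still fall on either side. Compound 3 differs from compound 1 in more than one place, so it does not settle this.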